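Replacing tert-butyl with fluoro on the shared core

The source may hold more compounds than are shown below. What is called first, only, known or untested is meant among the compounds shown, and "the series" means these compounds.

Compound 1 (`CCc1ccc(SCc2ccc(C(=O)Nc3ccccc3N)cc2)cc1`) and compound 2 (`CC(C)(C)c1ccc(SCc2ccc(C(=O)Nc3ccccc3N)cc2)cc1`) share one core and differ in a single substituent on an aromatic carbon. In a functional assay on HeLa cells (Homo sapiens) for inhibition, read by CCK-8 assay, with a stated time of 72 h, tested at 2 uM (on this read-out lower numbers stand for less inhibition of growth and higher numbers for more inhibition of growth at the one concentration tested), compound 1 gives 30.8% and compound 2 gives 9.73%. Compound 2 is therefore the lower of the two, with a gap beyond the scatter.

The next compound is compound 3 (`Nc1ccccc1NC(=O)c1ccc(CSc2ccc(F)cc2)cc1`), with fluoro in place of tert-butyl on an aromatic carbon, para to a large group: fluoro in place of tert-butyl on an aromatic carbon. Going by the values given here, only one measured step bears on this change, the one with tert-butyl in place of ethyl on that same carbon: a number 21.1 percentage points lower from compound 1 to compound 2 (beyond the scatter). Among the compounds with values here, this step is modest, and no measured compound yet carries fluoro, so it gives direction more than size. With that single step as the guide, a rise on leaving tert-butyl is expected, of similar size but with wide uncertainty. The expected change is a number 22.3 percentage points higher from compound 2 to compound 3 (beyond the scatter). For compound 3 the estimated value is 32%, with an expected range of 13% to 58%.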

Compound 3, percent growth inhibition at one concentration: 27.9%
The estimate for compound 3 lay 4.1 percentage points above the measured number, within the range that was stated.
By their numbers in this assay, from the lowest: compound 2; then compounds 3 and 1 (each within the scatter of the next).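

Notes on the position on the aromatic carbon para to a large group: in this assay fluoro in place of tert-butyl gives a number 18.2 percentage points higher from compound 2 to compound 3 (beyond the scatter) and so reverses, from the other direction, the fall seen on going from ethyl to tert-butyl. Fluoro in place of ethyl gives a number 2.9 percentage points lower from compound 1 to compound 3 (within the scatter) so these two groups cannot be told apart at the one concentration tested, even though they are very different groups. Among the three compounds, only compound 2 stands apart, with steps to both compound 1 and compound 3 beyond the scatter, so the position tolerates at least two different substituents with no separable change in growth inhibition, and tert-butyl is the one group that lowers the reading. No measurement offered here explains why tert-butyl differs from the other two groups.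

As far as these compounds go, with three substituents, it remains open whether the reading depends on the number of heavy atoms in the group or on something particular to tert-butyl, and a plain hydrogen, a chlorine, a methoxy group or an amine at this carbon would help to separate those readings. A single-concentration read-out also leaves open how the compounds would rank across a full range of concentrations.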